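The compounds below may be only part of what the source reports. "The series", "measured", "known", "first", "only" and "open" are said of these compounds alone.

Measured so far in an ADME assay on L6 cells (Rattus norvegicus) for cytotoxicity, read by resazurin assay, with a stated time of 70 h; on this read-out lower numbers stand for stronger inhibition and higher numbers for weaker inhibition: compound 1 `c1ccc(OCCCCOc2cccc(-c3cc4ccc(C5=NCCN5)cc4o3)c2)cc1` gives 5800 nM; compound 2 `c1ccc(OCCCCCOc2cccc(-c3cc4ccc(C5=NCCN5)cc4o3)c2)cc1` gives 3700 nM; compound 3 `CC(C)NC(=N)c1ccc2cc(-c3cccc(OCCCCCCOc4ccccc4)c3)oc2c1` gives 10100 nM.

Compound 3 holds the highest number of the three in this assay. Within the data shown here, its nearest neighbour is compound 1, within the scatter, and its furthest is compound 2, beyond the scatter; compound 3 differs from each of these in two places, so no single step is attached to either gap.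

Compound 4 `c1ccc(OCCCCCCOc2cccc(-c3cc4ccc(C5=NCCN5)cc4o3)c2)cc1` differs from compound 3 in one place: a group of 5 heavy atoms (3 carbon, 2 nitrogen; one five-membered non-aromatic ring with 2 hetero atoms) in place of a group of 6 heavy atoms (4 carbon, 2 nitrogen; no ring), on an aromatic carbon. Among the measured compounds shown here, the only measured step, a 1.6-fold lower number from compound 1 to compound 2 (0.20 log units; within the scatter), concerns the chain and stays within the scatter; no measured step covers this exchange itself. Compounds 1 and 2 carry the entering group, and their values sit at or below that of compound 3.

Compound 4 is therefore expected to land near compounds 1 and 2, a step of a 2.3-fold lower number from compound 3 to compound 4 (0.37 log units; beyond the scatter), that may not clear the scatter. The estimate for compound 4 is 4300 nM, range 1800 nM to 10000 nM.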

Compound 4, half-maximal inhibitory concentration: 1800 nM
Estimate against measurement, compound 4: 2.4-fold (0.38 log units) above, within the range that was stated.
By their numbers in this assay, from the lowest: compound 4; then compounds 2, 1 and 3 (each within the scatter of the next, the first and the last beyond it).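

In this assay, among these compounds, with the chain held constant, placing the five-membered non-aromatic ring on this aromatic carbon instead of the open-chain group gives a 5.6-fold lower number from compound 3 to compound 4 (0.75 log units; beyond the scatter), the first one-place reading of this exchange. With the ring held constant, extending the chain now gives steps beyond the scatter, a 2.1-fold lower number from compound 2 to compound 4 (0.31 log units; beyond the scatter) and a 3.2-fold lower number from compound 1 to compound 4 (0.51 log units; beyond the scatter), whereas the earlier 1.6-fold lower number from compound 1 to compound 2 (0.20 log units; within the scatter) stayed within it. Compound 4 therefore carries the lowest number of the four, but nothing at hand accounts for either change.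

As far as these compounds go, whether the ring exchange gives a similar step on the shorter chains of compound 1 and compound 2 remains open. Also open, from the compounds shown here alone, are how a longer chain would read in this assay and how a primary amine would read on this aromatic carbon.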